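Chloro to Bromo: What to Expect for Compound 4

The source may report more compounds than this note shows. Statements on the series, on what has been measured and on what is new or still open speak of the compounds shown alone.

Measured compounds:
compound 1 `Cc1c(C(=O)/C=C/c2ccc(Cl)cc2)[n+]([O-])c2ccccc2[n+]1[O-]` gives 16000 nM
compound 2 `Cc1c(C(=O)/C=C/c2ccc(Cl)c(Cl)c2)[n+]([O-])c2ccccc2[n+]1[O-]` gives 15400 nM
compound 3 `COc1cc(/C=C/C(=O)c2c(C)[n+]([O-])c3ccccc3[n+]2[O-])cc(OC)c1OC` gives 5220 nM

All three were tested in a functional assay on CCRF-CEM cells (Homo sapiens) for inhibition, with a stated time of 3 days; a higher number here means a weaker inhibitor, a lower number a stronger inhibitor. Compound 1 carries the highest number of the three. Compound 2 lies within the scatter of compound 1, so the two cannot be told apart; compound 3 lies lower by a margin beyond the scatter.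

Compound 4 `Cc1c(C(=O)/C=C/c2ccc(Br)cc2)[n+]([O-])c2ccccc2[n+]1[O-]` differs from compound 1 in a single place: bromo in place of chloro on an aromatic carbon. For the measured compounds named here, no measured compound carries a bromo group, so no step speaks directly to this exchange. Going by the values given here, the only measured single-point step, a 1.0-fold lower number from compound 1 to compound 2 (0.02 log units; within the scatter), also concerned a halogen on that carbon-only aromatic ring and stayed within the scatter. On that basis the exchange of one halogen for another is expected to move the number little, if at all, and in no reliable direction: the expected step is a 1.1-fold lower number from compound 1 to compound 4 (0.06 log units; within the scatter) in this assay. Compound 4 is therefore estimated at 14000 nM, with a likely range from 6000 nM to 35000 nM.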

Compound 4, half-maximal inhibitory concentration: 11600 nM
For compound 4 the middle estimate is 1.2-fold (0.08 log units) above the measured one; measured number inside the range.
By their numbers in this assay, from the lowest: compound 3; then compounds 4, 2 and 1 (each within the scatter of the next).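

In this assay, for the compounds shown here, putting bromo in place of chloro on this aromatic carbon gives a 1.4-fold lower number from compound 1 to compound 4 (0.14 log units; within the scatter) and so provides the first direct reading of this exchange: the halogen at this place can change from chloro to bromo with no real effect on the number. Replacing 3,4-dichlorophenyl with 4-bromophenyl gives a 1.3-fold lower number from compound 2 to compound 4 (0.12 log units; within the scatter) as well, so compound 1, compound 2 and compound 4 cannot be told apart in this assay, whichever of these halogen patterns they carry. Nothing available explains why these halogen changes make so little difference.

As far as these compounds go, whether an amine or a carboxylic acid on this aromatic carbon would move the number beyond the scatter remains open. From the compounds shown here alone, it is equally open whether fluoro or iodo at this place would behave like chloro and bromo.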